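This account rests on a few compounds, and the source may have more. Where it says the series, first, only, none or still open, it means among the compounds named here.

Measured in an assay for binding affinity to Melanocortin receptor 4 (Homo sapiens); on this read-out higher numbers stand for weaker inhibition and lower numbers for stronger inhibition:

Compound 1 `COc1ccc(Br)cc1CCc1c(F)cccc1C(=O)/N=C(\N)NCCCCN(C)Cc1ccccc1`: 5.1 nM
Compound 2 `CCN(CC)CCCC(C)/N=C(/N)NC(=O)c1cccc(F)c1CCc1cc(Br)ccc1OC`: 4.3 nM

For the measured compounds named here, compound 1 and compound 2 sit within the scatter of each other, so the two numbers show no difference worth reading; no step between them is counted. Compound 3 `COc1ccc(Br)cc1CCc1c(F)cccc1C(=O)/N=C(\N)NCCCN1CCN(C)CC1` differs from compound 1 by 4-methylpiperazin-1-yl in place of (benzyl(methyl)amino)methyl on a saturated chain carbon, three bonds along the chain from an amine nitrogen. Going by the values given here, no step of this kind has been measured, so its size is open. The leaving group carries one aromatic ring of carbon only, the entering group none; a modest weakening is expected, a 2.4-fold higher number from compound 1 to compound 3 (0.37 log units; beyond the scatter), possibly within the scatter. For compound 3 the estimate in this assay is 12 nM, range 4 nM to 40 nM.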

Compound 3, inhibition constant: 64 nM
The estimate for compound 3 lay 5.3-fold (0.73 log units) below the measured number, outside the stated range (above it).
By their numbers in this assay, from the lowest: compounds 2 and 1 (each within the scatter of the next); then compound 3.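

In this assay, the saturated chain carbon three bonds along the chain from an amine nitrogen proves sensitive to the group it carries: 4-methylpiperazin-1-yl in place of (benzyl(methyl)amino)methyl gives a 13-fold higher number from compound 1 to compound 3 (1.10 log units; beyond the scatter) in the first step measured in the series. The earlier pair showed no such separation, as its two numbers lay within the scatter. Nothing at hand accounts for the size of this step.

Still open, on these data alone, is whether the step follows the departure of the aromatic ring of carbon or the arrival of the piperazine ring. A 4-benzylpiperazin-1-yl group at this place would separate the two.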